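Adding a second ethyl to the amine of compound 3

This account rests on a few compounds, and the source may have more. Where it says the series, first, only, none or still open, it means among the compounds named here.

Measured compounds:
compound 1, `CCCN(CCC)Cc1ccc(Cl)c(-c2ccccc2OC)c1`, in an assay on isolated protein for binding affinity to 5-hydroxytryptamine receptor 1E (Homo sapiens); a higher number here means a weaker inhibitor, a lower number a stronger inhibitor: > 10000 nM, a limit of the assay
compound 2, `COc1ccccc1-c1cc(C2CCNC2)ccc1Cl`, in this assay: 770 nM
compound 3, `CCNCc1ccc(Cl)c(-c2ccccc2OC)c1`, in this assay: > 10000 nM, a limit of the assay

In this assay compound 3 does not give a number but only a limit, > 10000 nM. It shares this with one other compound: the limit of > 10000 nM in this assay, at which 2 of the 3 values shown sit. Compound 4 `CCN(CC)Cc1ccc(Cl)c(-c2ccccc2OC)c1` differs from compound 3 by ethyl in place of hydrogen on an amine nitrogen; cut one bond further out, this reads ethylamino to diethylamino. Going by the values given here, two measured steps touch compound 3. The step that the two limits leave unreadable from compound 1 to compound 3 exchanges dipropylamino for ethylamino on the same chain carbon and gives no reading: both of its ends are limits. The step of an at least 12-fold higher number from compound 2 to compound 3 (1.11 log units; beyond the scatter) concerns the swap of pyrrolidin-3-yl for (ethylamino)methyl and says nothing about a second ethyl on the nitrogen. Compound 4 sits between compound 1 and compound 3 in the size of its amine, and each of those gave only a limit. Therefore compound 4 is expected to remain at the limit, an expected step that the limit leaves unreadable from compound 3 to compound 4. Compound 4 is estimated at 15000 nM, within 5000 nM to 50000 nM.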

Compound 4, inhibition constant: > 10000 nM
Compound 4: no number, only a limit (the forecaster's own chance of this, stated with the estimate: 80%); the middle value is on the limit's open side.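

In this assay compound 4 gives > 10000 nM as a limit of the assay. The steps from compound 3 to compound 4 and from compound 1 to compound 4 cannot be read, and the second ethyl on the amine nitrogen adds a third amine of this series to the same limit: the limit of > 10000 nM in this assay, at which 3 of the 4 values shown sit. Going by these compounds alone, the one readable step is an at least 12-fold higher number from compound 2 to compound 4 (1.11 log units; beyond the scatter) and it leaves compound 2, with its pyrrolidin-3-yl group, as the only compound of the four with a number in this assay.

The shared limit hides any differences among the ethylamino, diethylamino and dipropylamino compounds. As far as these compounds go, it remains open whether a smaller group on the same chain carbon, such as methylamino or a plain amino group, or a ring amine such as piperidin-3-yl on the aromatic carbon, would give a number.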